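Swapping the Urea Substituent on a Shared Core

This account rests on a few compounds, and the source may have more. Where it says the series, first, only, none or still open, it means among the compounds named here.

Compound 1 `O=S(=O)(Nc1ccc2c(-c3ccncc3)c[nH]c2c1)c1ccccc1` and compound 2 `O=C(NOCc1ccccc1)Nc1ccc2c(-c3ccncc3)c[nH]c2c1` share the same core and differ only in the group carried on its amine nitrogen. In a physicochemical assay for lipophilicity, at pH 7.4 (a higher number here means a more lipophilic compound, a lower number a more polar compound), compound 1 gives 2.01, while compound 2 gives 3.54. Compound 2 thus holds the highest of the two numbers, and its nearest neighbour, compound 1, sits a gap below it that lies beyond the usual scatter.

Compound 3 `CN(C(=O)Nc1ccc2c(-c3ccncc3)c[nH]c2c1)c1ccccc1` has not yet been measured in this assay. It differs from compound 2 in a single place: methyl(phenyl)amino in place of (benzyloxy)amino on a carbonyl carbon. Among the measured compounds shown here, no step between measured compounds follows this particular change, so any expectation rests on compound 2 alone, whose value in this assay is 3.54. The step expected here, a number 0.16 log units higher from compound 2 to compound 3 (within the scatter), is small and upward, or none beyond the scatter. Compound 3 is accordingly estimated at 3.7, within a range from 3.2 to 4.2.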

Compound 3, distribution coefficient: 2.93
For compound 3 the middle estimate is 0.77 log units above the measured one; measured number below the stated range.
By their numbers in this assay, from the lowest: compound 1; then compound 3; then compound 2.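

In this assay the group on this carbonyl carbon proves to matter: methyl(phenyl)amino in place of (benzyloxy)amino gives a number 0.61 log units lower from compound 2 to compound 3 (beyond the scatter) and so moves the number beyond the scatter. The change does this although both groups carry one six-membered aromatic ring of carbon only and neither has a net charge, so keeping that ring does not keep the value. The leaving group has 1 hydrogen-bond donor and 1 hydrogen-bond acceptor and the entering group has 0 of each, but no measurement here explains the step.

Open, on these data alone, is where a phenylamino or a benzylamino group on the same carbonyl carbon would stand relative to compound 2 and compound 3. Also open, as far as these compounds go, is how a group with a carboxylic acid or a morpholine at this place would read in this assay.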